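Dropping a tert-butyl group: what the free carboxy may do

A few compounds are considered here, and "the series" means these few. Any claim that something is new, unique, unknown or untested is made for them only; others in the source may bear on it.

Measured so far:
compound 1, `CCCCCCCCCCCCCC1=C(O)C(=O)C=C(NCCCC(=O)O)C1=O`, gives 8%
compound 2, `CCCCCCCCCCCCCC1=C(OC)C(=O)C=C(NCCCC(=O)OC(C)(C)C)C1=O`, gives 72%

In a functional assay on GM15850 cells (Homo sapiens) for inhibition, read by flow cytometry, with a stated time of 16 h, tested at 5 uM (a higher number here means a stronger effect of the compound at the concentration tested, a lower number a weaker effect), compound 2 stands highest of the two numbers measured, and compound 1 is the nearest, sitting well below it by more than the usual scatter. Compound 2 and compound 1 differ in two places at once, so nothing can be said about which of the two changes matters.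

Compound 3, `CCCCCCCCCCCCCC1=C(OC)C(=O)C=C(NCCCC(=O)O)C1=O`, has not yet been measured. It differs from compound 2 in one place only: hydrogen in place of tert-butyl on an oxygen next to a carbonyl group. Compound 3 shares its free carboxy with compound 1, whose value in this assay is low, while keeping the methoxy of compound 2.

Compound 3 is expected to fall below compound 2, by a step of about a number 47 percentage points lower from compound 2 to compound 3 (beyond the scatter) in this assay, which is beyond the scatter. The estimate for compound 3 is 25%, with a likely range from 5% to 55%.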

Compound 3, a percentage reported as activity, at one concentration (the size of the read-out at that concentration, not a potency): 41%
For compound 3 the middle estimate is 16 percentage points below the measured one; the range from low to high includes it.
By their numbers in this assay, from the lowest: compound 1; then compound 3; then compound 2.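

In this assay, the change from tert-butoxycarbonyl to carboxy, taken alone with the methoxy kept, gives a number 31 percentage points lower from compound 2 to compound 3 (beyond the scatter), so the tert-butyl on this oxygen matters for the read-out by itself. With the free carboxy kept, methyl in place of hydrogen on an oxygen on an unsaturated carbon gives a number 33 percentage points higher from compound 1 to compound 3 (beyond the scatter), so a free carboxy does not fix the read-out at a low level, and the second place counts as well. Nothing measured here explains why either change has this effect.

The compounds shown leave open whether the tert-butyl group is special or whether another ester would serve as well. A methyl or ethyl group on the same oxygen, or an amide in place of the ester, would help to separate these possibilities.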